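The source may hold more compounds than are shown below. What is called first, only, known or untested is meant among the compounds shown, and "the series" means these compounds.

Working notes on the series. Compound 3 `O=C(c1ccc(F)c(F)c1)N1CCc2nc(COc3cccc(F)c3)oc2C1` gives 71% in a functional assay on HEK293 cells for positive allosteric modulation of metabotropic glutamate receptor 5 (Homo sapiens), read by calcium flux (a lower number here means a smaller maximal response, a higher number a larger maximal response), the low end of the three numbers, but with every gap to it within the scatter: compound 1 `O=C(c1ccc(F)cc1)N1CCc2nc(COc3cccc(F)c3)oc2C1` gives 78% and compound 2 `O=C(c1ccccc1)N1CCc2nc(COc3cccc(F)c3)oc2C1` gives 73%. The steps of a number 5 percentage points lower from compound 1 to compound 2 (within the scatter), a number 7 percentage points lower from compound 1 to compound 3 (within the scatter) and a number 2 percentage points lower from compound 2 to compound 3 (within the scatter) all stay within the scatter. Compound 4 `O=C(c1cc(F)cc(F)c1)N1CCc2nc(COc3cccc(F)c3)oc2C1` is the next member; relative to compound 3 the change is 3,5-difluorophenyl in place of 3,4-difluorophenyl on a carbonyl carbon. Among the compounds with values here, no measured step moves a fluorine between positions on this ring; the steps that bear on it only add or remove fluorine there, and none exceeded the scatter. Compound 4 is therefore expected to show a number 1 percentage points higher from compound 3 to compound 4 (within the scatter), no step beyond the scatter. The estimate for compound 4 is 72%, range 60% to 84%.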

Compound 4, largest response reached (reported as percent of maximum), in percent of the reference or control that the assay uses: 42%
Compound 4: middle estimate off by 30 percentage points, on the high side, and the stated range ends above it.
By their numbers in this assay, from the lowest: compound 4; then compounds 3, 2 and 1 (each within the scatter of the next).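

In this assay, the arrangement of the two fluorines on the aromatic ring at this carbonyl carbon matters, not only their presence: with the same atoms joined differently, the result is a number 29 percentage points lower from compound 3 to compound 4 (beyond the scatter). The 3,5-difluorophenyl group also stands apart from the other two groups, with a number 31 percentage points lower from compound 2 to compound 4 (beyond the scatter) and a number 36 percentage points lower from compound 1 to compound 4 (beyond the scatter), whereas all earlier steps here stayed within the scatter. Nothing available explains this difference.

Still open, from the compounds shown here alone, is whether 3-fluorophenyl or 3,5-dichlorophenyl on the same carbonyl carbon would give a similarly small maximal response.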